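Nitro to amino on the pyrimidine core: cytotoxicity notes

This account rests on a few compounds, and the source may have more. Where it says the series, first, only, none or still open, it means among the compounds named here.

The series shares a core carrying a (2,4,6-trimethylphenyl) group and a uracil-bearing two-carbon chain. Compound 1 `Cc1cc(C)c(Oc2nc(NCCn3ccc(=O)[nH]c3=O)ncc2Cl)c(C)c1` is the ether-linked member; in an ADME assay on MT4 cells (Homo sapiens) for cytotoxicity, read by MTT assay, with a stated time of 5 days (on this read-out higher numbers stand for lower toxicity in this test and lower numbers for higher toxicity in this test), compound 1 gives 2490 nM. Compound 2 `Cc1cc(C)c(Nc2nc(NCCn3ccc(=O)[nH]c3=O)ncc2[N+](=O)[O-])c(C)c1` carries the aryl through an amino link and a nitro group on the core. For compound 2 the assay reports only a limit, >= 3330 nM, and not a number. Compound 2 therefore sits at the limit of >= 3330 nM in this assay, at which 1 of the 2 values shown sits, so its true position is known only as a bound. Among the measured compounds shown here, no step between measured compounds can be computed from these two entries.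

Compound 3 `Cc1cc(C)c(Nc2nc(NCCn3ccc(=O)[nH]c3=O)ncc2N)c(C)c1` is the next member. It differs from compound 2 by amino in place of nitro on an aromatic carbon. With compound 2 sitting at the limit of >= 3330 nM in this assay, at which 1 of the 2 values shown sits, the step that the limit leaves unreadable from compound 2 to compound 3 is expected to stay within the usual scatter of this assay, and a limit rather than a number is considered the more likely outcome. For compound 3 the estimate in this assay is 4000 nM, expected between 1500 nM and 12000 nM.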

Compound 3, half-maximal cytotoxic concentration: > 199000 nM
Compound 3 was reported as a limit; the forecaster's own chance of this, stated with the estimate: 60%; middle value at least 49-fold (1.69 log units) from the limit.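

In this assay compound 3 is reported only as a limit, > 199000 nM. Among the compounds shown here, compound 2 is also reported only as a limit, >= 3330 nM, so no step between compound 2 and compound 3 can be read. The compounds shown leave open how large the cytotoxicity change is for amino in place of nitro on an aromatic carbon.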